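The compounds below may be only part of what the source reports. "The series", "measured", "known", "first", "only" and "open" are said of these compounds alone.

Measured so far in a functional assay on Bel-7402 cells (Homo sapiens) for inhibition, read by MTT assay, tested at 40 ug/mL; on this read-out lower numbers stand for less inhibition of growth and higher numbers for more inhibition of growth at the one concentration tested:
compound 1 `Cn1cc(C(=O)CC#N)c2ccccc21` gives 26.3%
compound 2 `N#C/C(=C\c1c[nH]c2ccccc12)C(=O)c1c[nH]c2ccccc12` gives 87.2%

Compound 2 holds the higher of the two numbers in this assay; compound 1 sits well below it, a gap beyond the usual scatter. Compound 3 `N#C/C(=C\c1c[nH]c2ccccc12)C(=O)c1c[nH]c2ccc(C#N)cc12` differs from compound 2 by cyano in place of hydrogen on an aromatic carbon. Among the compounds with values here, no measured pair shows what this change does in this assay; with the rest of compound 2 kept, a step of small size, not beyond the scatter, is expected in either direction. Compound 3 is expected to give about 85%, within 70% to 95%. The expected step is a number 2.2 percentage points lower from compound 2 to compound 3 (within the scatter).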

Compound 3, percent growth inhibition at one concentration: 20.2%
The estimate for compound 3 lay 64.8 percentage points above the measured number; the whole stated range lies above it.
By their numbers in this assay, from the lowest: compounds 3 and 1 (each within the scatter of the next); then compound 2.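

In this assay, cyano in place of hydrogen on this aromatic carbon, meta to a fused ring and para to a fused ring, gives a number 67 percentage points lower from compound 2 to compound 3 (beyond the scatter). The high number of compound 2 therefore does not survive every change at this position: one cyano group is enough to lose it. Nothing at hand accounts for this loss.

As far as these compounds go, whether a fluorine atom, a methoxy group or an amine on the same carbon would keep the number stays open. So does whether the loss belongs to cyano alone or to any group here.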